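This account rests on a few compounds, and the source may have more. Where it says the series, first, only, none or still open, it means among the compounds named here.

Measured in an ADME assay on MT4 cells (Homo sapiens) for cytotoxicity, read by MTT assay, with a stated time of 5 days; a higher number here means that more compound is tolerated, a lower number that less compound is tolerated:
compound 1 `COc1cc(-c2ccc(C#N)cc2)ccc1[C@H](O)c1ccnc(Nc2ccc(C#N)cc2)n1` gives 9070 nM
compound 2 `COc1cc(-c2ccc(C#N)cc2)ccc1[C@@H](O)c1ccnc(Nc2ccc(C#N)cc2)n1` gives 33100 nM
compound 3 `N#Cc1ccc(Nc2nccc(C(O)c3ccc(-c4ccc(C#N)cc4)cc3Cl)n2)cc1` gives 7540 nM

Compound 2 has the highest number of the three, and compounds 1 and 3 both lie lower, beyond the scatter. The next step leads to compound 4 `N#Cc1ccc(Nc2nccc([C@H](O)c3ccc(-c4ccc(C#N)cc4)cc3Cl)n2)cc1`, with chloro in place of methoxy on an aromatic carbon. Among the compounds with values here, the only measured step, a 3.6-fold higher number from compound 1 to compound 2 (0.56 log units; beyond the scatter), involves configuration alone (the fact that compounds 1 and 2 differ only in the configuration as drawn), so it gives no direct reading on this exchange. It does show the size of change that configuration alone can bring in this series. The nearest guide is compound 3, which also carries chloro but is drawn without a configuration, at 7540 nM. On that basis, a lower number than for compound 2 is expected in this assay, probably beyond the scatter. The expected size of the change is a 2.8-fold lower number from compound 2 to compound 4 (0.44 log units; beyond the scatter). For compound 4 the estimated value is 12000 nM, with an expected range from 5000 nM to 30000 nM.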

Compound 4, half-maximal cytotoxic concentration: 28100 nM
Estimate against measurement, compound 4: 2.3-fold (0.37 log units) below; the range from low to high includes it.
By their numbers in this assay, from the lowest: compounds 3 and 1 (each within the scatter of the next); then compounds 4 and 2 (each within the scatter of the next).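

In this assay, the aromatic carbon ortho to a large group takes chloro in place of methoxy with a 1.2-fold lower number from compound 2 to compound 4 (0.07 log units; within the scatter), so with both compounds drawn R, this exchange gives no separation. Before this, chloro could be compared only through compound 3, which is drawn without a configuration and so gave no clean reading of the exchange. The remaining gap, a 3.7-fold higher number from compound 3 to compound 4 (0.57 log units; beyond the scatter), lies beyond the scatter and matches the earlier step of a 3.6-fold higher number from compound 1 to compound 2 (0.56 log units; beyond the scatter) in direction, with the higher number on the R form in both pairs, and it involves no change of substituent: the fact that one of compounds 3 and 4 is drawn with a defined configuration and the other without, at the place where they differ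

Still open, from the compounds shown here alone, is whether chloro and methoxy also read alike with the S configuration at the carbinol carbon. Also open, going by these compounds, is how an amine, a carboxylic acid or a longer alkoxy chain on the same aromatic carbon would read in this assay.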